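This account rests on a few compounds, and the source may have more. Where it says the series, first, only, none or still open, it means among the compounds named here.

Working notes on the series. Compound 2 `Cc1nnc(CNc2nc(N)nc3ccn(Cc4ccccn4)c23)o1` carries the shared core with a ((5-methyl-1,3,4-oxadiazol-2-yl)methyl)amino group. In an ADME assay on HEK293 cells (Homo sapiens) for cytotoxicity, read by ATP content, with a stated time of 6 h (on this read-out higher numbers stand for lower toxicity in this test and lower numbers for higher toxicity in this test), compound 2 gives > 24000 nM, which is a limit of the assay and not a number. Compound 1 `Cc1ccc(CNc2nc(N)nc3ccn(Cc4ccccn4)c23)nc1` gives > 24000 nM in this assay, again a limit. Compound 3 `CC(C)c1cc(CNc2nc(N)nc3ccn(Cc4ccccn4)c23)no1` gives > 24000 nM, also a limit. All three values sit at the limit of > 24000 nM in this assay, at which 3 of the 3 values shown sit. The steps a step that the two limits leave unreadable from compound 1 to compound 2, a step that the two limits leave unreadable from compound 1 to compound 3 and a step that the two limits leave unreadable from compound 2 to compound 3 therefore carry no readable size. Compound 4 `Cc1cnc(COc2nc(N)nc3ccn(Cc4ccccn4)c23)o1` differs from compound 2 by (5-methyl-1,3-oxazol-2-yl)methoxy in place of ((5-methyl-1,3,4-oxadiazol-2-yl)methyl)amino on an aromatic carbon. Going by the values given here, no measured step gives a readable size for a change of this kind. Compound 4 is estimated to give 30000 nM in this assay, between 12000 nM and 80000 nM. The step that the limit leaves unreadable from compound 2 to compound 4 is expected to stay within the scatter.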

Compound 4, half-maximal cytotoxic concentration: > 24000 nM
Compound 4: a limit, no number; the forecaster's own chance of this, stated with the estimate: 75%; the middle value is on the limit's open side.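

Compound 4, like compound 2, stands at a limit and not a number, so no size can be read for the step between them. The compounds shown leave open what half-maximal cytotoxic concentration any of them has in this assay: the limit of > 24000 nM in this assay, at which 4 of the 4 values shown sit.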